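Replacing methyl with ethoxy in compound 1

This account rests on a few compounds, and the source may have more. Where it says the series, first, only, none or still open, it means among the compounds named here.

Within the data shown here, in a functional assay on SGC-7901 cells (Homo sapiens) for cytotoxicity, read by MTT assay, with a stated time of 48 h (on this read-out lower numbers stand for stronger inhibition and higher numbers for weaker inhibition), compound 1 `Cc1ccccc1-c1nnc(SCCn2c([N+](=O)[O-])cnc2C)o1` gives 32300 nM as the higher of the two numbers measured so far. Among the measured compounds shown here, the only measured neighbour is compound 2 `COc1ccc(-c2nnc(SCCn3c([N+](=O)[O-])cnc3C)o2)cc1` with 10200 nM as its number. Compound 3 `CCOc1ccccc1-c1nnc(SCCn2c([N+](=O)[O-])cnc2C)o1` has not been measured yet. Its change from compound 1 is ethoxy in place of methyl on an aromatic carbon, ortho to a large group, which comes to ethoxy in place of methyl on an aromatic carbon while the rest of the structure stays as it is. For the measured compounds named here, only one measured step bears on this: a 3.2-fold lower number from compound 1 to compound 2 (0.50 log units; beyond the scatter) for 4-methoxyphenyl in place of 2-methylphenyl, a modest change beyond the scatter. That step also takes away the methyl and brings in an oxygen-linked group, but the group sits elsewhere on the ring, so it guides only loosely. Going by the values given here, compound 2 at 10200 nM is thus the sole guide, and it points toward lower numbers, with a smaller step likely here. The expected move is a 1.6-fold lower number from compound 1 to compound 3 (0.21 log units; within the scatter) and it may not clear the scatter. In this assay the expected value for compound 3 is 20000 nM with 8000 nM and 50000 nM as the estimated ends of its range.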

Compound 3, half-maximal inhibitory concentration: 30300 nM
Estimate against measurement, compound 3: 1.5-fold (0.18 log units) below; the measured number falls inside the stated range.
By their numbers in this assay, from the lowest: compound 2; then compounds 3 and 1 (each within the scatter of the next).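

In this assay, putting ethoxy in place of methyl on this aromatic carbon, ortho to a large group, gives a 1.1-fold lower number from compound 1 to compound 3 (0.03 log units; within the scatter), so the two groups cannot be told apart here. The added oxygen and hydrogen-bond acceptor of ethoxy at this position therefore do not by themselves reproduce the step beyond the scatter seen with the 4-methoxyphenyl group, a 3.2-fold lower number from compound 1 to compound 2 (0.50 log units; beyond the scatter). Among these compounds, nothing measured so far explains why methyl and ethoxy read alike at this position.

On these data alone, it remains open whether an amine, a hydroxyl group or a longer chain such as butoxy on this same carbon would also stay within the scatter of compound 1, or whether one of them would move the number clearly in either direction. Also open, as far as these compounds go, is what ethoxy would do at the place on the ring held by the methoxy group of compound 2, since a single change at that place would separate the effect of the position from that of the group.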